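The source may hold more compounds than are shown below. What is called first, only, known or untested is meant among the compounds shown, and "the series" means these compounds.

Compound 1 `c1ccc(OCC2[C@H]3CN(Cc4cnc5ccccc5c4)C[C@@H]23)cc1`: in an in vitro ADME assay on microsomes from liver (Homo sapiens) for metabolic stability, tested at 1 uM (a lower number here means slower removal, a higher number faster removal of the compound), compound 1 gives < 5.3 mL/min/kg, which is a limit of the assay and not a number.
Compound 2 `c1ccc(OCC2[C@H]3CN(Cc4nc5ccccc5n4C4CC4)C[C@@H]23)cc1`: for compound 2 the result is "not determined" (no result reported).
Compound 3 `Cn1c(CN2C[C@@H]3C(COc4cc(F)ccc4F)[C@@H]3C2)nc2ccccc21`: in this assay compound 3 gives > 18.7 mL/min/kg, again a limit rather than a number.

Among the measured compounds shown here, compound 3 therefore stands at a limit, as does compound 1, while compound 2 carries no number at all, so no step between measured compounds can be sized and no spread across the three can be stated. Compound 4 `Cn1c(CN2C[C@@H]3C(COc4ccc(Cl)cn4)[C@@H]3C2)nc2ccccc21` has not yet been measured. It differs from compound 3 in one place: 5-chloropyridin-2-yl in place of 2,5-difluorophenyl on an oxygen on a saturated carbon. For the measured compounds named here, no measured pair shows what such a change does in this assay, so the direction is open and only a step within the usual scatter is assumed. The expected step of an at least 1.0-fold lower number from compound 3 to compound 4 (0.01 log units; that floor lies within the scatter) is accordingly small. Compound 4 is estimated at 18 mL/min/kg, within a range of 8 mL/min/kg to 35 mL/min/kg.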

Compound 4, clearance: 12.3 mL/min/kg
The estimate for compound 4 lay 1.5-fold (0.17 log units) above the measured number; low and high end bracket the measured number.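

Compound 4 is the only compound shown with a single number in this assay, so this place on the oxygen now has one firm reference point. Among the compounds shown here, putting 5-chloropyridin-2-yl in place of 2,5-difluorophenyl gives an at least 1.5-fold lower number from compound 3 to compound 4 (0.18 log units; that floor lies within the scatter), the first reading of this change, and it does not establish a difference beyond the scatter of repeated measurements. This size is only a floor, and the real step may be larger, because compound 3 carries a limit and not a number: the limit of > 18.7 mL/min/kg in this assay, at which 1 of the 4 values shown sits.

The compounds shown leave open how large the step really is and whether the nitrogen or the chlorine matters more, as the two enter together and no compound shown separates them. Also open, on these data alone, is how the clearance would respond to an amine or a carboxylic acid at this place.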